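Imidazolylmethyl Ether Replaces Benzyl Ether on a Glycoside Scaffold

A few compounds are considered here, and "the series" means these few. Any claim that something is new, unique, unknown or untested is made for them only; others in the source may bear on it.

Measured compounds:
compound 1 `NCCCCCOC[C@H]1O[C@@H](OCCc2c[nH]c3ccccc23)[C@H](OCc2ccccc2)C[C@@H]1OCc1ccccc1`, 4100 nM
compound 2 `CO[C@@H]1O[C@H](COCCCCCN)[C@@H](OCc2ccccc2)[C@H](OCc2ccccc2)[C@H]1OCc1ccccc1`, 2400 nM

Both compounds were tested in an assay on isolated protein for binding affinity to somatostatin receptor type 1 (Homo sapiens); a lower number here means a stronger inhibitor, a higher number a weaker inhibitor. Compound 1 gives 4100 nM, and compound 2 gives 2400 nM; the two numbers lie within the usual scatter of each other, so the data shown do not separate them. Compound 1 is therefore not set apart from compound 2 on what has been measured.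

Compound 3 `NCCCCCOC[C@H]1O[C@@H](OCCc2c[nH]c3ccccc23)[C@H](OCc2c[nH]cn2)C[C@@H]1OCc1ccccc1` has not yet been measured in this assay. Its difference from compound 1 is 1H-imidazol-4-yl in place of phenyl on a saturated chain carbon bound to an oxygen on a saturated carbon. Going by the values given here, no pair of measured compounds shows this difference, so there is no measured step to lean on; the expectation rests only on the values of compound 1 and compound 2.

Given that, the change from compound 1 to compound 3 is expected to stay within, or only a little beyond, the scatter, with no firm direction: the estimated step is a 1.4-fold lower number from compound 1 to compound 3 (0.14 log units; within the scatter). For compound 3 in this assay the estimated value is 3000 nM, with a range from 800 nM to 12000 nM.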

Compound 3, inhibition constant: 6800 nM
For compound 3 the middle estimate is 2.3-fold (0.36 log units) below the measured one, within the range that was stated.
By their numbers in this assay, from the lowest: compounds 2, 1 and 3 (each within the scatter of the next, the first and the last beyond it).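

In this assay, going by these compounds alone, the exchange of benzyloxy for (1H-imidazol-4-yl)methoxy gives a 1.7-fold higher number from compound 1 to compound 3 (0.22 log units; within the scatter), the first direct reading of any change at this place, on a saturated chain carbon bound to an oxygen on a saturated carbon. Phenyl, with 0 hydrogen-bond donors and 0 hydrogen-bond acceptors, can thus give way to 1H-imidazol-4-yl, with 1 hydrogen-bond donor and 1 hydrogen-bond acceptor, and the two compounds remain inseparable on this measurement. Nothing available explains this result or shows what the ring contributes to the binding value.

This single pair leaves open whether the result holds for other rings at this place, such as pyridin-4-yl or 4-hydroxyphenyl, or for a group of another kind, such as a carboxylic acid or an amine on the same saturated chain carbon. It also leaves open whether the same exchange would read alike at the other benzyloxy group of the core of compound 1, or on a core carrying a different chain in place of the aminopentyl ether.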